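The compounds below may be only part of what the source reports. "The series", "measured", "known", "first", "only" and "open" are said of these compounds alone.

Compound 1 `O=S1(=O)C=C(OCc2ccccc2)C(Cc2ccccc2)(Cc2ccccc2)O1` gives, in an ADME assay on HEL cells (Homo sapiens) for cytotoxicity, with a stated time of 3 days (on this read-out higher numbers stand for lower toxicity in this test and lower numbers for higher toxicity in this test), a reading of 200000 nM. For the measured compounds named here, compound 3 `CC1(Cc2ccccc2)OS(=O)(=O)C=C1OCc1ccccc1` gives 68000 nM in this assay, and the only single change measured here, a 2.9-fold lower number from compound 1 to compound 3 (0.47 log units; beyond the scatter), is modest. Compound 2 `CCC1(Cc2ccccc2)OS(=O)(=O)C=C1OCc1ccc([N+](=O)[O-])cc1` gives in this assay only a limit, < 200000 nM, not a number. Compound 2 therefore sits at the limit of < 200000 nM in this assay, at which 1 of the 3 values shown sits, with its true value unknown. Compound 4 `CCC1(Cc2ccccc2)OS(=O)(=O)C=C1OCC#N` differs from compound 2 by cyano in place of 4-nitrophenyl on a saturated chain carbon bound to an oxygen on an unsaturated carbon. Going by the values given here, no measured step shares this group or this place, and since the one step available, a 2.9-fold lower number from compound 1 to compound 3 (0.47 log units; beyond the scatter), was small, no step beyond the scatter is expected. Compound 4 is estimated at 100000 nM, within 30000 nM to 200000 nM. The expected step is thus a step that the limit leaves unreadable from compound 2 to compound 4.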

Compound 4, half-maximal cytotoxic concentration: > 200000 nM
Compound 4: a limit, no number; the forecaster's own chance of this, stated with the estimate: 30%; at least 2.0-fold (0.30 log units) between middle value and limit.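

In this assay compound 4 gives > 200000 nM, a limit of the assay and not a number. Putting cyano in place of 4-nitrophenyl gives a number no lower from compound 2 to compound 4 (the limit leaves the size open), the first step seen on a saturated chain carbon bound to an oxygen on an unsaturated carbon. It shows the direction of this change on the read-out, but its size cannot be read.

Going by these compounds, what an amine or a carboxylic acid would give at this place stays open. So does whether this change would act alike on the core of compound 1.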